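The compounds below may be only part of what the source reports. "The series", "measured", "known", "first", "only" and "open" are said of these compounds alone.

Measured so far:
Compound 1 `CC(C)Nc1cc(Cl)cc2c(-c3ccnc(NC4CCCC4)n3)c(-c3ccc(F)cc3)nn12`; in an ADME assay on Vero cells (Chlorocebus sabaeus) for cytotoxicity (on this read-out higher numbers stand for lower toxicity in this test and lower numbers for higher toxicity in this test), compound 1 gives > 40000 nM, a limit of the assay.
Compound 2 `Fc1ccc(-c2nn3c(N4CCCCC4)cc(Cl)cc3c2-c2ccnc(NC3CCCC3)n2)cc1`; in this assay compound 2 gives > 40000 nM, again a limit of the assay.

Compound 2 thus stands at the upper limit, not at a number, like compound 1: the limit of > 40000 nM in this assay, at which 2 of the 2 values shown sit. Among the measured compounds shown here, the one measured step, a step that the two limits leave unreadable from compound 1 to compound 2, is unreadable in size for that reason. Compound 3 `CN(C)c1cc(Cl)cc2c(-c3ccnc(NC4CCCC4)n3)c(-c3ccc(F)cc3)nn12` differs from compound 2 by dimethylamino in place of piperidin-1-yl on an aromatic carbon. For the measured compounds named here, it touches the same position as the unreadable step, so no measured step gives a usable size for it. Because both measured compounds sit at the limit of > 40000 nM in this assay, at which 2 of the 2 values shown sit, the plain expectation is that compound 3 also reaches that limit. Compound 3 is estimated at 40000 nM, in a range from 20000 nM to 100000 nM. The step this estimate means is a number no higher from compound 2 to compound 3 (the limit leaves the size open), most likely reported once more as a limit rather than a number.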

Compound 3, half-maximal cytotoxic concentration: > 40000 nM
Compound 3 ended at the assay's limit; the forecaster's own chance of this, stated with the estimate: 85%; the middle value lies on the limit itself.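

Compound 1, compound 2 and compound 3 all end at a limit in this assay, so no step among them can be read: the limit of > 40000 nM in this assay, at which 3 of the 3 values shown sit.

The compounds shown leave open whether these three differ at all in this assay, and which group on that aromatic carbon would give a readable number.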